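Trading Trifluoroethoxy for Methoxy: Compound 1 to Compound 4

This account rests on a few compounds, and the source may have more. Where it says the series, first, only, none or still open, it means among the compounds named here.

Compound 1 `O=C(/C=C/c1ccc(OCC(F)(F)F)cc1)NNC(=O)c1ccncc1` carries a 2,2,2-trifluoroethoxy group on its aromatic ring. In an ADME assay on THP-1 cells (Homo sapiens) for cytotoxicity, read by MTT assay, with a stated time of 72 h (on this read-out higher numbers stand for weaker inhibition and lower numbers for stronger inhibition), compound 1 gives "not determined" (no result reported), so it has no number of its own to stand on. Compound 3 `COc1ccc(/C=C/C(=O)N[C@@H]2CONC2=O)cc1` is in the same position, giving "not determined" (no result reported) in this assay. Going by the values given here, the only compound with a reported number is compound 2 `COc1ccc(/C=C/C(=O)N/N=c2/[nH]ncc3ccccc23)cc1`, which in this assay gives 437000 nM, a very high concentration that speaks for little cytotoxicity toward these cells.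

Compound 4 `COc1ccc(/C=C/C(=O)NNC(=O)c2ccncc2)cc1` has not yet been measured. It differs from compound 1 in one place: hydrogen in place of trifluoromethyl on a saturated chain carbon bound to an oxygen on an aromatic ring. With this change compound 4 shares its methoxy-bearing aromatic ring with compound 2 and compound 3, while keeping the rest of the shape of compound 1.

Among the compounds with values here, no step between two measured compounds is available, so the data do not show how this change moves the read-out. In this assay a step from compound 1 to compound 4 is expected to be small, with no clear direction and most likely within the scatter. Compound 4 is expected to remain weakly cytotoxic, because compound 2 gives 437000 nM as its closest measured relative. For compound 4 the estimated concentration is 300000 nM, expected to fall between 60000 nM and 1500000 nM, with a fair chance that only a limit is reported.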

Compound 4, half-maximal inhibitory concentration: 168000 nM
Compound 4: the middle estimate sits 1.8-fold (0.25 log units) above what was measured; low and high end bracket the measured number.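

In this assay, going by these compounds alone, compound 1 gives "not determined" (no result reported) and so offers no step to compound 4 that can be read. The compounds shown leave open how the change from 2,2,2-trifluoroethoxy to methoxy moves this read-out. Nothing shown offers a measured explanation for the result of compound 4.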